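The source may report more compounds than this note shows. Statements on the series, on what has been measured and on what is new or still open speak of the compounds shown alone.

Measured so far:
compound 1 `O=C(Nc1ccc(OC(F)(F)F)cc1)c1cc(F)ccc1O` — 810 nM
compound 2 `N#Cc1ccc(NC(=O)c2ccc3cccnc3c2O)c(Cl)c1` — 550 nM
compound 3 `O=C(Nc1cc(C(F)(F)F)cc(C(F)(F)F)c1)c1cc(F)ccc1O` — 500 nM

In a functional assay on Jurkat cells (Homo sapiens) for cytotoxicity, read by luminescence and CellTiter-Glo, with a stated time of 3 days (on this read-out lower numbers stand for stronger inhibition and higher numbers for weaker inhibition), compound 2 gives 550 nM, the second highest of the three numbers. Compound 3 gives a number within the scatter of it, and compound 1 also lies within the scatter, so the three measured compounds cannot be ordered on these data.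

Compound 4 `N#Cc1ccc(NC(=O)c2ccc3cccnc3c2O)cc1` has not yet been measured in this assay. It differs from compound 2 by hydrogen in place of chloro on an aromatic carbon. Going by the values given here, no measured pair shows this change, so its size is not known from the data. Compound 4 is expected to give 800 nM in this assay, with a range from 300 nM to 2500 nM. The expected step is a 1.5-fold higher number from compound 2 to compound 4 (0.16 log units; within the scatter), a small rise that may not exceed the scatter.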

Compound 4, half-maximal inhibitory concentration: 180 nM
Compound 4: middle estimate off by 4.4-fold (0.65 log units), on the high side; the measured number lies below the stated range.
By their numbers in this assay, from the lowest: compound 4; then compounds 3, 2 and 1 (each within the scatter of the next).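

In this assay, going by these compounds alone, hydrogen in place of chloro on this aromatic carbon, ortho to a large group and meta to a cyano group, gives a 3.1-fold lower number from compound 2 to compound 4 (0.49 log units; beyond the scatter), the only one-place change read so far. The chloro at this position is therefore not required for activity here, and the number responds to this single change. No evidence at hand bears on the cause of this step.

As far as these compounds go, whether a fluoro, a methyl or an amine at this carbon would give a number near that of compound 4 stays open. From the compounds shown here alone, whether the same change carries over to other cores also stays open.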